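From 4-bromophenyl to 2-methylphenyl in compound 3

The compounds below may be only part of what the source reports. "The series", "measured", "known", "first", "only" and "open" are said of these compounds alone.

Of the compounds shown here, three have numbers so far in a physicochemical assay for lipophilicity (on this read-out higher numbers stand for higher lipophilicity and lower numbers for lower lipophilicity), and they are well spread. Compound 1 `C[C@H]1CC[C@@H]2[C@@H](OC(=O)[C@]23CC(c2c(Cl)cccc2Cl)=NO3)[C@]2(C)C(=O)C=C[C@@]12O` gives 2.67 and compound 2 `Cc1ccccc1C1=NO[C@]2(C1)C(=O)O[C@@H]1[C@H]2CC[C@H](C)[C@]2(O)C=CC(=O)[C@@]12C` gives 1.86 while compound 3 `C[C@H]1CC[C@@H]2[C@@H](OC(=O)[C@]23CC(c2ccc(Br)cc2)N(c2ccccc2)O3)[C@]2(C)C(=O)C=C[C@@]12O` gives 4 as the highest of the three. Compound 1 is its nearest neighbour and compound 2 lies furthest below it, both clearly beyond the scatter.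

Compound 4 `Cc1ccccc1C1C[C@@]2(ON1c1ccccc1)C(=O)O[C@@H]1[C@H]2CC[C@H](C)[C@]2(O)C=CC(=O)[C@@]12C` has not been measured. It differs from compound 3 by one exchange 2-methylphenyl in place of 4-bromophenyl on a saturated ring carbon in which 2-methylphenyl takes the place of 4-bromophenyl on a saturated ring carbon.

For the measured compounds named here, only one measured step bears on this, and it brings in the same 2-methylphenyl group, there in place of 2,6-dichlorophenyl on a carbon with a double bond to nitrogen. That step gives a number 0.81 log units lower from compound 1 to compound 2 (beyond the scatter) and so points downward. Going by the values given here, it is only a partial guide, since the group leaving is different and sits elsewhere on the molecule, and no measured pair shows 4-bromophenyl being replaced. Less halogen leaves here, so a fall in the same direction but of smaller size seems likely.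

The expected change is a number 0.40 log units lower from compound 3 to compound 4 (beyond the scatter) as a modest estimate. In this assay compound 4 is estimated at 3.6 with an expected range from 3.1 to 4.1 around that figure.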

Compound 4, partition coefficient: 3.64
Beside the measured number, compound 4's estimate is 0.04 log units below it; the measured number falls inside the stated range.
By their numbers in this assay, from the lowest: compound 2; then compound 1; then compound 4; then compound 3.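

The earlier compounds shown here held no change at this saturated ring carbon next to the ring nitrogen, and here, in this assay, putting 2-methylphenyl in place of 4-bromophenyl gives a number 0.36 log units lower from compound 3 to compound 4 (beyond the scatter) as the reading. The two groups match in heavy atom count, in their single six-membered aromatic ring and in having no hydrogen-bond donors or acceptors, so the step swaps a bromine for a carbon and also moves the substituent to a different place on the aromatic ring, and a single step cannot separate those two differences. The direction agrees with a number 0.81 log units lower from compound 1 to compound 2 (beyond the scatter) in the same assay, so among the steps shown, 2-methylphenyl coming in goes with a lower number at two different places and against two different departing groups. Nothing measured here explains the fall in either step.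

An unsubstituted phenyl group at this carbon would show how much each of the two substituents contributes on its own. On these data alone, how the number would respond to a ring carrying an amine or a carboxylic acid at the same carbon remains open.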